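Swapping methyl for fluoro on a shared core

The compounds below may be only part of what the source reports. "The series", "measured", "known", "first", "only" and "open" are said of these compounds alone.

Compound 3 `Cc1ccc(-c2cs/c(=N/NC(=O)CSc3nnnn3-c3ccccc3)n2-c2ccccc2)cc1` sits second highest of three in a functional assay on C6 cells (Rattus norvegicus) for cytotoxicity, read by MTT assay, with a stated time of 24 h, tested at 6 ug/mL (on this read-out higher numbers stand for a weaker effect at the one concentration tested and lower numbers for a stronger effect), giving 66.8%. Compound 1 `O=C(CSc1nnnn1-c1ccccc1)N/N=c1/scc(-c2ccc(Br)cc2)n1-c1ccccc1` gives 61.8% in this assay, and compound 2 `Cc1nnc(SCC(=O)N/N=c2/scc(-c3ccc(F)cc3)n2-c2ccccc2)s1` gives 74.3%; both lie within the scatter of compound 3. Among the measured compounds shown here, the one step that bears directly on the ring in question, a number 5 percentage points higher from compound 1 to compound 3 (within the scatter), stayed within the scatter. Compound 4 `O=C(CSc1nnnn1-c1ccccc1)N/N=c1/scc(-c2ccc(F)cc2)n1-c1ccccc1` differs from compound 3 in a single place: fluoro in place of methyl on an aromatic carbon. For the measured compounds named here, compound 2 also carries fluoro, but it differs from compound 3 in a second place as well, so it offers no clean step. Going by the values given here, with the only measured change on this ring within the scatter, no step beyond the scatter is expected in this assay. Compound 4 is therefore estimated at 68%, between 57% and 79%. The expected step is a number 1.2 percentage points higher from compound 3 to compound 4 (within the scatter), within the scatter.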

Compound 4, a percentage reported as activity, at one concentration (the size of the read-out at that concentration, not a potency): 74.9%
For compound 4 the middle estimate is 6.9 percentage points below the measured one; low and high end bracket the measured number.
By their numbers in this assay, from the lowest: compounds 1, 3, 2 and 4 (each within the scatter of the next, the first and the last beyond it).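

In this assay, among the compounds shown here, fluoro in place of methyl gives a number 8.1 percentage points higher from compound 3 to compound 4 (within the scatter) while fluoro in place of bromo gives a number 13.1 percentage points higher from compound 1 to compound 4 (beyond the scatter) and is the first step on this ring to pass the scatter, pointing to a weaker effect with fluoro than with bromo at the one concentration tested. With fluoro held fixed, 1-phenyl-1H-tetrazol-5-yl in place of 5-methyl-1,3,4-thiadiazol-2-yl on the sulfur gives a number 0.6 percentage points higher from compound 2 to compound 4 (within the scatter) and so shows no real change. No measurement at hand explains these steps. From the compounds shown here alone, whether an amine or a carboxylic acid on this aromatic carbon would shift the read-out stays open. So does whether the step from bromo to fluoro holds with 5-methyl-1,3,4-thiadiazol-2-yl on the sulfur.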